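Taking one bromo off compound 2

This account rests on a few compounds, and the source may have more. Where it says the series, first, only, none or still open, it means among the compounds named here.

In an ADME assay on HEK293 cells (Homo sapiens) for cytotoxicity, read by reporter gene assay and resazurin assay, with a stated time of 48 h (on this read-out lower numbers stand for higher toxicity in this test and higher numbers for lower toxicity in this test), compound 1 `COc1ccccc1C(=O)Nc1cccc(Cl)c1` gives > 100000 nM, which is a limit of the test and not a number. Compound 2 `COc1c(Br)cc(Br)cc1C(=O)Nc1cccc(Cl)c1` gives > 100000 nM, which is also a limit. For the measured compounds named here, compound 2 therefore stands with the only other measured compound, at the limit of > 100000 nM in this assay, at which 2 of the 2 values shown sit. Compound 3 `COc1ccc(Br)cc1C(=O)Nc1cccc(Cl)c1` has hydrogen in place of bromo on an aromatic carbon, ortho to a methoxy group: hydrogen in place of bromo on an aromatic carbon. In this assay, no change beyond the usual scatter is expected, because compound 2 sits at the limit of > 100000 nM in this assay, at which 2 of the 2 values shown sit. The estimated size of the change is a number no higher from compound 2 to compound 3 (the limit leaves the size open). Compound 3 is expected at 100000 nM, within an estimated range of 50000 nM to 200000 nM.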

Compound 3, half-maximal cytotoxic concentration: > 100000 nM
Compound 3 was reported as a limit (the forecaster's own chance of this, stated with the estimate: 85%); the middle value lies on the limit itself.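

Compound 3 reads as a limit, just as compound 1 and compound 2 do, so no step among these three compounds can be read: the limit of > 100000 nM in this assay, at which 3 of the 3 values shown sit.

As far as these compounds go, what removing or adding a bromo does to toxicity in this assay stays open.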